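A few compounds are considered here, and "the series" means these few. Any claim that something is new, unique, unknown or untested is made for them only; others in the source may bear on it.

Measured so far:
compound 1, `O=C(NC1CCCNC1)c1ccccc1OCc1ccccc1Cl`: > 100000 nM
compound 2, `O=C(Nc1cccnc1)c1ccccc1OCc1cccc(Cl)c1`: 1400 nM

In an assay on lysate for inhibition of phosphatidylcholine:ceramide cholinephosphotransferase 2 (Homo sapiens), read by HPLC, with stated times of 30 min and 2 h (a lower number here means a stronger inhibitor, a higher number a weaker inhibitor), compound 1 gives only a limit of the assay, > 100000 nM. For the measured compounds named here, compound 2 gives 1400 nM, the only real number seen here. The value of compound 1 sits at the limit of > 100000 nM in this assay, at which 1 of the 2 values shown sits, a limit and not a number, so compound 2 stands alone as a point of reference. Compound 3 `Cc1ccc(Cl)cc1COc1ccccc1C(=O)Nc1cccnc1` differs from compound 2 by methyl in place of hydrogen on an aromatic carbon. Going by the values given here, no measured step is available to lean on; the change is expected to stay within the usual scatter, a 1.1-fold lower number from compound 2 to compound 3 (0.03 log units; within the scatter). Compound 3 is therefore expected to give 1300 nM, in a range from 400 nM to 4500 nM.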

Compound 3, half-maximal inhibitory concentration: 1100 nM
Estimate against measurement, compound 3: 1.2-fold (0.07 log units) above; the measured number falls inside the stated range.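

Methyl in place of hydrogen on this aromatic carbon, ortho to a large group and para to a chloro group, gives a 1.3-fold lower number from compound 2 to compound 3 (0.10 log units; within the scatter) in this assay. For the compounds shown here, this is the first readable step, and it shows that this position takes a methyl with no measurable shift in the number. Nothing measured here bears on the reason for this result. The compounds shown leave open how a methoxy group, an amine or a longer chain would read at this same carbon.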